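Diaryl sulfoxide series: oxadiazole for thiadiazole on the chain

The source may hold more compounds than are shown below. What is called first, only, known or untested is meant among the compounds shown, and "the series" means these compounds.

Working notes on a small set of diaryl-substituted sulfoxides. In an assay on HEK293 cells for inhibition of sodium-dependent dopamine transporter (Homo sapiens), read by scintillation counting, with stated times of 5 min and 1 min (on this read-out lower numbers stand for stronger inhibition and higher numbers for weaker inhibition), compound 1 `[O-][S+](Cc1cc(Br)cs1)C(c1ccccc1)c1ccccc1` gives 13700 nM and compound 3 `[O-][S+](Cc1cccs1)C(c1ccc(F)cc1)c1ccc(F)cc1` gives 4000 nM. Compound 2 `Cc1nnc(C[S+]([O-])C(c2ccccc2)c2ccccc2)s1` is reported in this assay as "not active" (no number reported), with no number attached; it therefore stands outside the measured part of the set and cannot be placed against compound 1 or compound 3 on a numerical scale.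

Compound 4 `Cc1noc(C[S+]([O-])C(c2ccccc2)c2ccccc2)n1` has not yet been tested in this assay. Its difference from compound 2 is 3-methyl-1,2,4-oxadiazol-5-yl in place of 5-methyl-1,3,4-thiadiazol-2-yl on a saturated chain carbon bound to a sulfur. Both groups are five-membered aromatic rings with three hetero atoms and the same count of donors and acceptors, so the change is small in size. Going by the values given here, no measured pair in the set shows what this exchange does, and compound 2 itself supplies no number to move from. Among the compounds with values here, the expectation is no step in this assay beyond the usual scatter, with a fair chance that compound 4 is again reported without a number. If a number is obtained, compound 4 is expected near 30000 nM, in a range from 8000 nM to 100000 nM.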

Compound 4, half-maximal inhibitory concentration: 56700 nM
Compound 4: middle estimate off by 1.9-fold (0.28 log units), on the low side; measured number inside the range.
By their numbers in this assay, from the lowest: compound 3; then compound 1; then compound 4.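

In this assay, going by these compounds alone, 3-methyl-1,2,4-oxadiazol-5-yl in place of 4-bromothiophen-2-yl on a saturated chain carbon bound to a sulfur gives a 4.1-fold higher number from compound 1 to compound 4 (0.62 log units; beyond the scatter), the first step in the set to show that the group at this position changes the read-out. It also gives this position a number for a five-membered aromatic ring with 3 hetero atoms, which compound 2 did not supply. The step between compound 2 and compound 4 cannot be read, as compound 2 carries no number, and nothing measured in the set accounts for the step that can be read.

Open, going by these compounds, is whether an amine or a carboxylic acid in this position would give a lower number than the rings seen so far. Also open, on these data alone, is whether the diaryl groups of compound 3 would shift the number of compound 4.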